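Compound 4 and the Exposure Left by an Open Chain

The compounds below may be only part of what the source reports. "The series", "measured", "known", "first", "only" and "open" are said of these compounds alone.

Values in an ADME assay on the whole organism (strain FVB) for pharmacokinetics, with Mus musculus as the target, read by LC-MS, at a dose of 30 mg/kg by the oral route (on this read-out higher numbers stand for higher exposure at the dose given and lower numbers for lower exposure), follow:

Compound 1 `CC(C)(N)CCOc1ccc([C@H]2CC[C@]3(CC2)OOC2(O3)C3CC4CC(C3)CC2C4)cc1` gives 1050 nM
Compound 2 `c1cc([C@H]2CC[C@]3(CC2)OOC2(O3)C3CC4CC(C3)CC2C4)ccc1OCC1CCNCC1` gives 465 nM
Compound 3 `N[C@H]1CC[C@@H](Oc2ccc([C@H]3CC[C@]4(CC3)OOC3(O4)C4CC5CC(C4)CC3C5)cc2)CC1` gives 1170 nM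

Compound 3 belongs to the upper pair of these numbers. Two measured steps fix that position (a 1.1-fold higher number from compound 1 to compound 3 (0.05 log units; within the scatter)) and (a 2.5-fold higher number from compound 2 to compound 3 (0.40 log units; beyond the scatter)).

Compound 4 `CC(C)(CN)Oc1ccc([C@H]2CC[C@]3(CC2)OOC2(O3)C3CC4CC(C3)CC2C4)cc1` differs from compound 3 in one place, with 1-(aminomethyl)-1-methylethyl in place of 4-aminocyclohexyl on an oxygen on an aromatic ring. A group with no ring thus replaces a six-membered ring of carbon only.

The closest evidence is the exchange of 3-amino-3-methylbutyl for 4-aminocyclohexyl at that same place, which also sets a group with no ring against that ring and stayed small (a 1.1-fold higher number from compound 1 to compound 3 (0.05 log units; within the scatter)). The two steps involving compound 2 were larger (a 2.3-fold lower number from compound 1 to compound 2 (0.35 log units; beyond the scatter)) and (a 2.5-fold higher number from compound 2 to compound 3 (0.40 log units; beyond the scatter)), so this place is not silent, but both were modest and both involve a piperidin-4-yl group, which compound 4 lacks.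

No step beyond the scatter is therefore expected in this assay, though a slight fall would not surprise. The expected change is small (a 1.4-fold lower number from compound 3 to compound 4 (0.14 log units; within the scatter)). Compound 4 is estimated at 850 nM with an expected range from 400 nM to 1800 nM.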

Compound 4, maximal plasma concentration: 529 nM
Compound 4: the middle estimate sits 1.6-fold (0.21 log units) above what was measured; low and high end bracket the measured number.
By their numbers in this assay, from the lowest: compounds 2, 4, 1 and 3 (each within the scatter of the next, the first and the last beyond it).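

In this assay, setting 1-(aminomethyl)-1-methylethyl in place of 4-aminocyclohexyl on the oxygen on the aromatic ring gives a step beyond the scatter (a 2.2-fold lower number from compound 3 to compound 4 (0.34 log units; beyond the scatter)), so a step of this size at this place does not depend on a piperidin-4-yl group. Removing the ring therefore has no single outcome across these compounds: compound 1 also has a group with no ring and stays within the scatter of compound 3, whereas compound 4 does not, even though it remains within the scatter of the other two compounds (a 1.1-fold higher number from compound 2 to compound 4 (0.06 log units; within the scatter)) and (a 2.0-fold lower number from compound 1 to compound 4 (0.30 log units; within the scatter)). Nothing available bears on what lies behind these differences.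

Going by these compounds, it remains open how an unbranched chain such as 2-aminoethyl, without the two methyl groups of compound 4, would compare at this place. On these data alone, since every group here carries an amine, it is also open whether a hydroxyl or an amide could take the place of that amine without lowering the number.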